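Aryl exchange on the saturated ring carbon

The source may report more compounds than this note shows. Statements on the series, on what has been measured and on what is new or still open speak of the compounds shown alone.

Within the data shown here, only two compounds have measured values so far. In a functional assay on PC-3 cells (Homo sapiens) for cytotoxicity, read by MTT assay, with a stated time of 72 h (a higher number here means a weaker inhibitor, a lower number a stronger inhibitor), compound 1 (`CNC(=O)c1cc(Oc2ccc(C3=NNC(c4ccc(C#N)cc4)C3)cc2)ccn1`) gives 9910 nM and compound 2 (`CNC(=O)c1cc(Oc2ccc(C3=NN(C(N)=S)C(c4cccc(Cl)c4Cl)C3)cc2)ccn1`) gives 15900 nM as its value. Compound 2 therefore stands within the scatter of compound 1, and the two numbers cannot be separated.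

Compound 3 (`CNC(=O)c1cc(Oc2ccc(C3=NN(C(N)=S)C(c4ccc(C#N)cc4)C3)cc2)ccn1`) departs from compound 2 in one place (4-cyanophenyl in place of 2,3-dichlorophenyl on a saturated ring carbon), with 4-cyanophenyl in place of 2,3-dichlorophenyl on a saturated ring carbon. Among the measured compounds shown here, no measured pair isolates this exchange, so any forecast rests on thin evidence. For the measured compounds named here, the only guide is compound 1, which also bears 4-cyanophenyl and whose value of 9910 nM in this assay does not stand apart from that of compound 2.

No step beyond the scatter is therefore expected in this assay, and the estimated 1.3-fold lower number from compound 2 to compound 3 (0.12 log units; within the scatter) stays inside it. Compound 3 is expected at 12000 nM with an estimated range from 4000 nM to 32000 nM in this assay.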

Compound 3, half-maximal inhibitory concentration: > 50000 nM
Compound 3: only a limit was reported; the forecaster's own chance of this, stated with the estimate: 8%; middle value at least 4.1-fold (0.61 log units) away from the limit.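

In this assay, compound 3 is reported only as a limit, not as a number: the limit of > 50000 nM in this assay, at which 1 of the 3 values shown sits.

On the saturated ring carbon, the aryl group does matter when the ring nitrogen carries the group of 3 heavy atoms: 4-cyanophenyl in place of 2,3-dichlorophenyl gives an at least 3.1-fold higher number from compound 2 to compound 3 (0.49 log units; beyond the scatter). The substituent on the amine nitrogen in the ring matters as well, since with 4-cyanophenyl held fixed, the group of 3 heavy atoms in place of a hydrogen atom gives an at least 5.0-fold higher number from compound 1 to compound 3 (0.70 log units; beyond the scatter), which makes compound 3 the weakest of the three compounds in this small set.

Going by these compounds, it remains open whether the step at the saturated ring carbon follows from gaining the nitrile or from losing the two chlorine atoms, and a 4-chlorophenyl or a plain phenyl group at this carbon would help separate the two. It is also open how 2,3-dichlorophenyl behaves with a hydrogen atom on the ring nitrogen, so the compounds shown cannot tell whether the two changes act independently of each other.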